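This account rests on a few compounds, and the source may have more. Where it says the series, first, only, none or still open, it means among the compounds named here.

Compound 1 `Fc1ccc(-c2nn3c(NC4CCCC4)nccc3c2-c2ccnc(NC3CCCC3)n2)cc1` was examined in an ADME assay on Vero cells (Chlorocebus sabaeus) for cytotoxicity; a higher number here means that more compound is tolerated, a lower number that less compound is tolerated. In this assay compound 1 gives > 40000 nM, which is a limit of the assay rather than a measured number. Compound 2 `Fc1ccc(-c2nn3c(N4CCCC4)nccc3c2-c2ccnc(NC3CCCC3)n2)cc1`, a close relative, gives > 40000 nM, again only a limit. Compound 3 `CC(C)(C)Nc1nccc2c(-c3ccnc(NC4CCCC4)n3)c(-c3ccc(F)cc3)nn12` gives > 40000 nM, once more a limit. Because (the limit of > 40000 nM in this assay, at which 3 of the 3 values shown sit), the steps a step that the two limits leave unreadable from compound 1 to compound 2, a step that the two limits leave unreadable from compound 1 to compound 3 and a step that the two limits leave unreadable from compound 2 to compound 3 cannot be read in size or direction. Compound 4 `CCCCOc1ccc(-c2nn3c(NC4CCCC4)nccc3c2-c2ccnc(NC3CCCC3)n2)cc1` differs from compound 1 in one place: butoxy in place of fluoro on an aromatic carbon. Within the data shown here, none of the measured steps touches this position, so they offer no direction for the change. Compound 4 is therefore expected to stay near the same limit, with an estimated value of 35000 nM, between 12000 nM and 80000 nM. The expected step is an at least 1.1-fold lower number from compound 1 to compound 4 (0.05 log units; that floor lies within the scatter).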

Compound 4, half-maximal cytotoxic concentration: > 40000 nM
Compound 4: a limit, no number; the forecaster's own chance of this, stated with the estimate: 60%; at least 1.1-fold (0.05 log units) between middle value and limit.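

Compound 1 and compound 4 both sit at a limit rather than a number, so the step between them cannot be read: the limit of > 40000 nM in this assay, at which 4 of the 4 values shown sit.

The compounds shown leave open whether butoxy in place of fluoro changes the result in this assay at all.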